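Adding a Second Chloro Group: From Compound 1 to Compound 3

The source may hold more compounds than are shown below. What is called first, only, known or untested is meant among the compounds shown, and "the series" means these compounds.

Measured compounds:
compound 1 `COc1ccc(-c2nc(C)c(C(=O)CSc3nc(-c4ccc(Cl)cc4)c(C#N)c(=O)[nH]3)s2)cc1` — 92.7%
compound 2 `COc1ccc(-c2nc(SCC(=O)c3sc(-c4ccccc4)nc3C)[nH]c(=O)c2C#N)cc1OC` — 69.8%

In a functional assay on U-87MG ATCC cells for antiproliferative activity against U-87 MG (Homo sapiens), read by MTT assay, with a stated time of 48 h, tested at 10 uM (a higher number here means a weaker effect of the compound at the concentration tested, a lower number a stronger effect), compound 1 gives 92.7%, the higher of the two numbers shown, meaning the weaker effect at the concentration tested. Compound 2 gives 69.8% in this assay, a gap that goes beyond the usual scatter, so compound 2 acts more strongly than compound 1 here.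

Compound 3 `COc1ccc(-c2nc(C)c(C(=O)CSc3nc(-c4ccc(Cl)c(Cl)c4)c(C#N)c(=O)[nH]3)s2)cc1` has not been measured. It differs from compound 1 in one place: chloro in place of hydrogen on an aromatic carbon. For the measured compounds named here, no pair of measured compounds that differ in just one place is available, so the size of this step cannot be read from the data. A single added chloro group is a small change, and compound 1 already sits near the weak end; the step of a number 4.7 percentage points lower from compound 1 to compound 3 (within the scatter) is expected to be small, likely within the scatter, if anything toward a slightly stronger effect. Compound 3 is therefore estimated at 88%, in the range 70% to 100%.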

Compound 3, a percentage reported as activity, at one concentration (the size of the read-out at that concentration, not a potency): 88.6%
Compound 3: the middle estimate sits 0.6 percentage points below what was measured; low and high end bracket the measured number.
By their numbers in this assay, from the lowest: compound 2; then compounds 3 and 1 (each within the scatter of the next).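

In this assay the change from 4-chlorophenyl to 3,4-dichlorophenyl gives a number 4.1 percentage points lower from compound 1 to compound 3 (within the scatter) and is the only step shown so far that can be read at a single place. It shows that, on the core of compound 1 and at the concentration tested, a second chloro group on this ring leaves the read-out within the usual scatter of repeated measurements. Nothing measured here gives a reason for this result.

From the compounds shown here alone, whether a different group on this same aromatic carbon, such as an amine or a carboxylic acid, would move the read-out beyond the scatter remains open. Also open, going by these compounds, is whether the second chloro group would have a similarly small effect if other parts of the molecule were changed.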